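This account rests on a few compounds, and the source may have more. Where it says the series, first, only, none or still open, it means among the compounds named here.

Working notes on the benzothiazolyl amide series, read against a functional assay on the whole organism with Mus musculus as the target, in the maximal electroshock model, with a stated time of 0.5 h; on this read-out lower numbers stand for an effect already at smaller amounts and higher numbers for an effect only at larger amounts of compound.

Compound 3, `O=C(Nc1nc2ccc([N+](=O)[O-])cc2s1)c1ccccc1C(=O)c1ccccc1`, gives 300 mg/kg in this assay. Compound 2, `O=C(Nc1nc2ccc(Br)cc2s1)c1ccccc1C(=O)c1ccccc1`, gives 300 mg/kg, so compound 3 stands level with compound 2 at the digits shown; together the two carry the highest numbers of the three measured. Compound 1, `Cc1ccc2nc(NC(=O)CCC(=O)c3ccccc3)sc2c1`, gives 100 mg/kg, a lower number than that of compound 3 and a gap beyond the usual scatter, but compound 1 carries a different acyl part, so its two values with compound 3 are not a single-point comparison.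

The step under consideration leads to compound 4, `Cc1ccc2nc(NC(=O)c3ccccc3C(=O)c3ccccc3)sc2c1`, not yet measured in this assay. It differs from compound 3 by methyl in place of nitro on an aromatic carbon.

Within the data shown here, one measured step bears on the same aromatic carbon: no change at the digits printed from compound 2 to compound 3 (within the scatter). Bromo and nitro at that place gave the same number, which suggests that the group there is not what sets the dose in this pair. Among the measured compounds shown here, no measured step covers methyl against nitro with the benzoylbenzoyl amide held fixed. For the measured compounds named here, the expectation for the step from compound 3 to compound 4 is therefore a small change or none beyond the scatter, a 1.5-fold lower number from compound 3 to compound 4 (0.18 log units; within the scatter), leaning lower only because compound 1, the one methyl-bearing member, gives 100 mg/kg. Compound 4 is estimated at 200 mg/kg, within a range from 100 mg/kg to 300 mg/kg.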

Compound 4, minimum effective dose: 300 mg/kg
Estimate against measurement, compound 4: 1.5-fold (0.18 log units) below; the measured number falls inside the stated range.
By their numbers in this assay, from the lowest: compound 1; then compounds 2, 3 and 4 (each within the scatter of the next).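

With the benzoylbenzoyl amide held fixed in this assay, the methyl step reads no change at the digits printed from compound 3 to compound 4 (within the scatter), and the comparison with bromo reads no change at the digits printed from compound 2 to compound 4 (within the scatter). This aromatic carbon has now carried three groups with no separation among them, and the tie extends beyond the earlier bromo and nitro pair: a single carbon enters where nitro's three heavy atoms, with their nitrogen and two oxygens, leave, and the number stays put. No measurement on hand explains why the three groups give the same number in this series.

Going by these compounds, it remains open whether a group of another kind at this carbon, such as an amine, a carboxylic acid or a longer alkyl chain, or plain hydrogen, would separate from these three with the benzoylbenzoyl amide in place. Compound 1 carries methyl with a different acyl part and gives 100 mg/kg, whereas compound 4 gives 300 mg/kg, so whether other groups at this carbon would also tie on the acyl part of compound 1 is unsettled.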